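This account rests on a few compounds, and the source may have more. Where it says the series, first, only, none or still open, it means among the compounds named here.

Measured so far:
- compound 1, `CC1=NN(S(=O)(=O)c2ccc(C)cc2)C(c2cc(Br)ccc2O)C1`, giving 33200 nM
- compound 2, `O=c1oc2ccccc2cc1C1=NN(S(=O)(=O)c2ccc([N+](=O)[O-])cc2)C(c2ccccc2)C1`, giving 46600 nM
- compound 3, `Cc1ccc(S(=O)(=O)N2N=C(c3cc4ccccc4oc3=O)CC2c2ccccc2)cc1`, giving 48600 nM

All three were tested in a functional assay on PC-3 cells (Homo sapiens) for cytotoxicity, read by MTT assay, with a stated time of 48 h; a lower number here means a stronger inhibitor, a higher number a weaker inhibitor. Compound 3 returns the highest of the three numbers, but its neighbours are close: compound 2 sits within the scatter of it, and even compound 1 differs from it by less than the scatter allows. So no order among these three compounds can be claimed.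

Compound 4, `CC(C)CNCC(=O)N1N=C(c2cc3ccccc3oc2=O)CC1c1ccccc1`, has not yet been measured. It departs from compound 3 by this change: ((isobutylamino)methyl)carbonyl in place of (4-methylphenyl)sulfonyl on an amine nitrogen in a ring. Among the compounds with values here, the only measured step, a 1.0-fold higher number from compound 2 to compound 3 (0.02 log units; within the scatter), concerns a substituent on the aromatic ring of the sulfonyl group and says nothing about removing that sulfonyl group altogether. Within the data shown here, there is thus no step that bears directly on the change to compound 4, and the three measured values lie in one narrow band.

On that basis compound 4 is expected to land near its predecessor, with a 1.2-fold lower number from compound 3 to compound 4 (0.08 log units; within the scatter) as the estimated step, and its value in this assay is estimated at 40000 nM, within a range from 15000 nM to 110000 nM.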

Compound 4, half-maximal inhibitory concentration: 1920 nM
Compound 4: middle estimate off by 21-fold (1.32 log units), on the high side; measured number outside the range, below it.
By their numbers in this assay, from the lowest: compound 4; then compounds 1, 2 and 3 (each within the scatter of the next).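

In this assay, placing ((isobutylamino)methyl)carbonyl instead of (4-methylphenyl)sulfonyl on the amine nitrogen in the ring gives a 25-fold lower number from compound 3 to compound 4 (1.40 log units; beyond the scatter) and thus a large change in the number. The earlier pair altered only a substituent on the aromatic ring of the sulfonyl group and gave a 1.0-fold higher number from compound 2 to compound 3 (0.02 log units; within the scatter) which lies within the scatter, whereas this result shows that replacing the whole group at this position can shift the number well beyond it. Nothing available explains this shift.

The change removes the sulfonyl group and its aromatic ring while adding a carbonyl and a chain with an amine, so the compounds shown cannot tell which of these parts matters. A plain acetyl group, or a piperidine or carboxylic acid in place of the isobutylamino part, would help separate them.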